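Aryl ketone variation at the enone terminus

The compounds below may be only part of what the source reports. "The series", "measured", "known", "first", "only" and "open" are said of these compounds alone.

Measured compounds:
compound 1 `COc1ccc(-c2cc3ccccc3nc2/C=C/C(=O)c2ccccc2)cc1` gives 6670 nM
compound 2 `COc1ccc(-c2cc3ccccc3nc2/C=C/C(=O)c2ccc(F)cc2)cc1` gives 6990 nM
compound 3 `COc1ccc(-c2cc3ccccc3nc2/C=C/C(=O)c2ccsc2)cc1` gives 7080 nM

In a functional assay on NCI-H460 cells (Homo sapiens) for antiproliferative activity, read by XTT assay, with a stated time of 72 h (on this read-out higher numbers stand for weaker inhibition and lower numbers for stronger inhibition), the three measured compounds sit close together: the steps of a 1.0-fold higher number from compound 1 to compound 2 (0.02 log units; within the scatter) and a 1.1-fold higher number from compound 1 to compound 3 (0.03 log units; within the scatter), as well as a 1.0-fold higher number from compound 2 to compound 3 (0.01 log units; within the scatter), all stay within the scatter. Compound 3 holds the highest of the three numbers, yet its neighbours lie so near that no order can be drawn. Compound 4 `COc1ccc(-c2cc3ccccc3nc2/C=C/C(=O)c2ccc[nH]2)cc1` differs from compound 3 by 1H-pyrrol-2-yl in place of thiophen-3-yl on a carbonyl carbon. The measured steps that bear on this place, phenyl to 4-fluorophenyl, phenyl to thiophen-3-yl and 4-fluorophenyl to thiophen-3-yl, all stayed within the scatter of this assay, so no step beyond the scatter is expected from compound 3 to compound 4 either. For compound 4 the estimated value in this assay is 7000 nM, with a range of 3000 nM to 16000 nM, an expected step of a 1.0-fold lower number from compound 3 to compound 4 (0.00 log units; within the scatter).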

Compound 4, half-maximal inhibitory concentration: > 10000 nM
Compound 4 gave a limit, no number (the forecaster's own chance of this, stated with the estimate: 5%); middle value at least 1.4-fold (0.15 log units) away from the limit.
By their numbers in this assay, from the lowest: compounds 1, 2 and 3 (each within the scatter of the next). At a limit, above all of these: compound 4.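

With 1H-pyrrol-2-yl on the carbonyl carbon, compound 4 gives a limit and not a number in this assay: the limit of > 10000 nM in this assay, at which 1 of the 4 values shown sits.

Its steps are floors only, an at least 1.4-fold higher number from compound 3 to compound 4 (0.14 log units; that floor lies within the scatter) and an at least 1.4-fold higher number from compound 2 to compound 4 (0.15 log units; that floor lies within the scatter) and an at least 1.4-fold higher number from compound 1 to compound 4 (0.17 log units; that floor lies within the scatter), so none of them establishes a loss. Still, this is the first hint that the position may not stay flat, and the entering ring is the only one shown with a hydrogen-bond donor.

From the compounds shown here alone, the actual value of compound 4 stays open. So does whether 1-methyl-1H-pyrrol-2-yl or furan-2-yl on the carbonyl carbon would sit with compound 3 or with compound 4.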